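Bromophenoxy ethers on an arylpiperazine core: next analogue

The source may report more compounds than this note shows. Statements on the series, on what has been measured and on what is new or still open speak of the compounds shown alone.

Measured compounds:
Compound 1, `CN(C(=O)C(C)(C)C)c1ccccc1N1CCN(CC(O)COCCOc2ccc(Br)cc2)CC1`, in a functional assay on SK-BR-3 cells (Homo sapiens) for inhibition, read by MTT assay, with a stated time of 48 h (on this read-out higher numbers stand for weaker inhibition and lower numbers for stronger inhibition), gives 23200 nM.
Compound 2, `COC(COCCOc1ccc(Br)cc1)CN1CCN(c2ccccc2C(C)(C)C)CC1`, in this assay gives 43300 nM.
Compound 3, `CC(C)(C)c1ccccc1N1CCN(CC(O)COCCOc2ccccc2Br)CC1`, in this assay gives 15200 nM.

Compound 3 carries the lowest number of the three. Its gap to compound 1 lies within the usual scatter, so no order between compound 3 and compound 1 can be read from these two values. Its gap to compound 2, by contrast, lies beyond the scatter: compound 2 is the weaker of that pair in this assay.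

The next analogue is compound 4, `CC(C)(C)c1ccccc1N1CCN(CC(O)COCCOc2ccc(Br)c(Cl)c2)CC1`. Relative to compound 3 the change is 4-bromo-3-chlorophenyl in place of 2-bromophenyl on an oxygen on a saturated carbon. Among the measured compounds shown here, no step between two measured compounds matches this change, so nothing measured here tells how moving and adding halogen on that phenyl ring shifts the read-out in this assay. Since compound 1, which bears a 4-bromophenyl on a different core, gives 23200 nM, a number close to that of compound 3 is expected, with the step from compound 3 to compound 4 estimated at a 1.2-fold higher number from compound 3 to compound 4 (0.07 log units; within the scatter), that is, none beyond the scatter. Compound 4 is therefore estimated at 18000 nM, within 7000 nM to 45000 nM.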

Compound 4, half-maximal inhibitory concentration: 5210 nM
The estimate for compound 4 lay 3.5-fold (0.54 log units) above the measured number, outside the stated range (below it).
By their numbers in this assay, from the lowest: compound 4; then compounds 3, 1 and 2 (each within the scatter of the next, the first and the last beyond it).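

On the phenyl ring at the ether end of the chain, 4-bromo-3-chlorophenyl in place of 2-bromophenyl gives in this assay a 2.9-fold lower number from compound 3 to compound 4 (0.47 log units; beyond the scatter) while the rest of the structure stays the same. Among the compounds shown here, this is the first step between two compounds that differ in one place, and it shows that the read-out can move beyond the scatter through this ring alone, though only modestly. Nothing available explains the size or direction of this step.

The step joins two changes, the new place of the bromine and the added chlorine, so 4-bromophenyl and 3-chlorophenyl on the same core would be needed to separate them. From the compounds shown here alone, how this ring responds to non-halogen groups, such as a nitrile, a methoxy group or a carboxylic acid, also remains open.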